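This account rests on a few compounds, and the source may have more. Where it says the series, first, only, none or still open, it means among the compounds named here.

Working notes on the chroman urea and thiourea series, read in a functional assay on T98G cells (Homo sapiens) for inhibition, read by MTT assay, with a stated time of 72 h; a higher number here means a weaker inhibitor, a lower number a stronger inhibitor.

Compound 1, `CC(C)NC(=O)NC1CC(C)(C)Oc2ccc(Cl)cc21`, reaches only the limit of > 100000 nM in this assay, a limit and not a number; it sits at the limit of > 100000 nM in this assay, at which 1 of the 3 values shown sits.

Compound 2, `CC1(C)CC(NC(=S)Nc2cccc(Cl)c2)c2cc(Br)ccc2O1`, gives 9000 nM in this assay. Compound 3, `COc1ccccc1NC(=S)NC1CC(C)(C)Oc2ccc(Br)cc21`, gives 42000 nM in this assay. Going by the values given here, the one measured step, a 4.7-fold higher number from compound 2 to compound 3 (0.67 log units; beyond the scatter), exchanges the aryl group on the thiourea nitrogen. Compound 2 therefore holds the lowest of the two numbers given, with compound 3 as its nearest neighbour at a distance beyond the scatter, and compound 1 known only as a limit.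

Compound 4, `CC1(C)CC(NC(=S)Nc2cccc([N+](=O)[O-])c2)c2cc(Br)ccc2O1`, keeps the core and the thiourea of compound 2 and differs only in nitro in place of chloro on an aromatic carbon. Among the compounds with values here, no measured step swaps one substituent for another on the same aryl ring; the only step on record, from compound 2 to compound 3, replaces the whole aryl group and was of modest size. The change here is smaller in kind, so no step beyond the scatter is expected, with a slight lean toward a higher number left open; the expected step is a 1.3-fold higher number from compound 2 to compound 4 (0.12 log units; within the scatter).

Compound 4 is thus estimated at 12000 nM in this assay, within a range of 4000 nM to 40000 nM.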

Compound 4, half-maximal inhibitory concentration: 4000 nM
Compound 4: the middle estimate sits 3.0-fold (0.48 log units) above what was measured; measured number inside the range.
By their numbers in this assay, from the lowest: compound 4; then compound 2; then compound 3. At a limit, above all of these: compound 1.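

On the aromatic carbon meta to a large group, in this assay, nitro in place of chloro gives a 2.3-fold lower number from compound 2 to compound 4 (0.35 log units; beyond the scatter) as its measured step, so a single substituent exchange at this place moves the number beyond the scatter. The earlier step, a 4.7-fold higher number from compound 2 to compound 3 (0.67 log units; beyond the scatter), replaced the whole aryl group and could not separate the effect of one place on the ring; the new step keeps the core, the thiourea and the ring, and it runs toward a lower number, with nitro entering and hydrogen-bond acceptors that chloro does not have coming with it. Nothing measured for this series bears on why this exchange lowers the number.

Going by these compounds alone, compound 1 stands at > 100000 nM, a limit and not a number, and it differs from the others in more than one place, so no step to it can be read. From the compounds shown here alone, whether an amine, a carboxylic acid or a methyl ester at this same ring carbon would follow nitro or chloro remains open, as does whether nitro would give a similar step with the ring's other substitution patterns or in the urea.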